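Aryl ether variation and cell cytotoxicity in one series

The compounds below may be only part of what the source reports. "The series", "measured", "known", "first", "only" and "open" are said of these compounds alone.

Measured so far:
Compound 1 `N#Cc1ccc(Nc2nc(Oc3c(Cl)cc(Cl)cc3Cl)c3ccccc3n2)cc1` gives 56000 nM in an ADME assay on MT4 cells (Homo sapiens) for cytotoxicity, read by MTT assay, with a stated time of 4 days; on this read-out higher numbers stand for lower toxicity in this test and lower numbers for higher toxicity in this test.
Compound 2 `N#Cc1ccc(Nc2nc(Oc3ccccc3Cl)c3ccccc3n2)cc1` gives 38000 nM in this assay.
Compound 3 `COc1cc(C#N)cc(Cl)c1Oc1nc(Nc2ccc(C#N)cc2)nc2ccccc12` gives 220000 nM in this assay.

Compound 2 gives the lowest of the three numbers, but its nearest neighbour compound 1 is within the scatter: a 1.5-fold lower number from compound 1 to compound 2 (0.17 log units; within the scatter). Compound 3 stands well apart, its number being far higher than that of compound 2.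

Compound 4 `N#Cc1ccc(Nc2nc(Oc3ccc(Br)cc3)c3ccccc3n2)cc1` is not yet measured. It differs from compound 2 in one place: 4-bromophenyl in place of 2-chlorophenyl on an oxygen on an aromatic ring. Among the compounds with values here, the only measured step that bears on this is the one from compound 1 to compound 2, where the halogen pattern of the phenyl on the oxygen was changed and the result was a 1.5-fold lower number from compound 1 to compound 2 (0.17 log units; within the scatter), within the scatter. A change of halogen and its place on that same phenyl is therefore expected to give no step beyond the scatter in this assay, and the expected step is a 1.2-fold higher number from compound 2 to compound 4 (0.07 log units; within the scatter). Compound 4 is estimated at 45000 nM, with a range from 15000 nM to 150000 nM.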

Compound 4, half-maximal cytotoxic concentration: 215000 nM
Compound 4: middle estimate off by 4.8-fold (0.68 log units), on the low side, outside the stated range (above it).
By their numbers in this assay, from the lowest: compounds 2 and 1 (each within the scatter of the next); then compounds 4 and 3 (each within the scatter of the next).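

In this assay the phenyl on this oxygen does respond to the change of halogen and its place, with a step beyond the scatter (a 5.7-fold higher number from compound 2 to compound 4 (0.75 log units; beyond the scatter)) and a second one, also beyond it (a 3.8-fold higher number from compound 1 to compound 4 (0.58 log units; beyond the scatter)). The earlier pair, 2-chlorophenyl and 2,4,6-trichlorophenyl, gave only a step within the scatter, so the response first appears with the 4-bromophenyl. The data hold nothing that explains this step, and the change alters the halogen and its place together, so neither can be credited alone.

A 4-chlorophenyl or a 2-bromophenyl on the same oxygen would separate halogen from place, and the compounds shown leave that question open. Also open, on these data alone, is how this position responds to a phenyl carrying an amine, a carboxylic acid or a longer alkoxy chain.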